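A few compounds are considered here, and "the series" means these few. Any claim that something is new, unique, unknown or untested is made for them only; others in the source may bear on it.

In an ADME assay on MDCK cells (Canis lupus familiaris) for cytotoxicity (on this read-out lower numbers stand for higher toxicity in this test and higher numbers for lower toxicity in this test), compound 1 (`O=[N+]([O-])C1=NNc2nc(C(F)(F)F)nn2C1c1c(O)cc(O)cc1O`) gives 252000 nM. Within the data shown here, compound 2 (`O=[N+]([O-])C1=NNc2ncnn2C1c1ccc(O)cc1O`) gives 90000 nM, the lower of the two numbers so far, and the gap between them lies beyond the usual scatter of repeated measurements.

Compound 3 (`O=[N+]([O-])C1=NNc2ncnn2C1c1c(O)cc(O)cc1O`) has not yet been measured. It differs from compound 2 in one place: hydroxy in place of hydrogen on an aromatic carbon. In words, a hydroxy group takes the place of hydrogen on an aromatic carbon, ortho to a large group and meta to two hydroxy groups.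

Among the measured compounds shown here, no two measured compounds differ in just one place, so the data hold no direct example of this change, and any expectation is a cautious one. For the measured compounds named here, the only other number, that of compound 1 at 252000 nM, lies above compound 2, and this is the sole hint for the direction. A small upward move is expected in this assay, one that may stay within the scatter. The expected change is estimated as a 1.6-fold higher number from compound 2 to compound 3 (0.19 log units; within the scatter). For compound 3 the estimated value is 140000 nM, with an expected range of 50000 nM to 350000 nM.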

Compound 3, half-maximal cytotoxic concentration: 119000 nM
The estimate for compound 3 lay 1.2-fold (0.07 log units) above the measured number; low and high end bracket the measured number.
By their numbers in this assay, from the lowest: compounds 2 and 3 (each within the scatter of the next); then compound 1.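

In this assay, putting a hydroxy group in place of hydrogen on this aromatic carbon, ortho to a large group and meta to two hydroxy groups, gives a 1.3-fold higher number from compound 2 to compound 3 (0.12 log units; within the scatter). That step lies within the scatter, so the two compounds cannot be told apart on this read-out, and this position accepts a hydroxy group without a measurable difference in this test. The new compound also opens a comparison at a second place on the molecule: hydrogen in place of trifluoromethyl on an aromatic carbon gives a 2.1-fold lower number from compound 1 to compound 3 (0.33 log units; beyond the scatter), a modest step, but one beyond the scatter. Nothing available explains either result.

Going by these compounds, at the first place, only hydrogen and hydroxy can be compared, so it remains open whether a methoxy group, an amine or a fluorine atom there would also leave the number within the scatter. At the second place, only trifluoromethyl and hydrogen can be compared, so a methyl group or a longer chain could fall anywhere relative to them.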